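The source may report more compounds than this note shows. Statements on the series, on what has been measured and on what is new or still open speak of the compounds shown alone.

Compound 1 `O=[N+]([O-])c1ccc(CSc2nnc(-c3ccc4c(c3)OCCO4)n2-c2ccccc2)cc1`: 48600 nM
Compound 2 `Fc1ccccc1CSc1nnc(-c2ccc3c(c2)OCCO3)n1-c1ccccc1`: 18600 nM
Compound 3 `Fc1cccc(F)c1CSc1nnc(-c2ccc3c(c2)OCCO3)n1-c1ccccc1`: 84200 nM

All three values come from a functional assay on BGC-823 cells (Homo sapiens) for antiproliferative activity, read by MTT assay, with a stated time of 24 h; on this read-out higher numbers stand for weaker inhibition and lower numbers for stronger inhibition. The compounds share one core and differ only in the aromatic ring on a saturated chain carbon bound to a sulfur. Compound 3 sits at the weak end of this small set. It is level with compound 1 within the scatter, as a 1.7-fold higher number from compound 1 to compound 3 (0.24 log units; within the scatter) shows, and only compound 2 gives a clearly lower number.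

The next compound is compound 4 `Brc1cccc(CSc2nnc(-c3ccc4c(c3)OCCO4)n2-c2ccccc2)c1`, which carries 3-bromophenyl in place of 2,6-difluorophenyl on a saturated chain carbon bound to a sulfur. For the measured compounds named here, no measured compound carries bromine, so the evidence is indirect. The closest guide is a 4.5-fold higher number from compound 2 to compound 3 (0.66 log units; beyond the scatter), a modest step from a single added fluoro. The swap of groups at this same place in a 2.6-fold lower number from compound 1 to compound 2 (0.42 log units; beyond the scatter) was also modest. Steps at this place have therefore stayed modest, and since compound 3 already stands at the top of the range, a move towards a lower number seems more likely than a further rise in this assay. The expected change is a 2.2-fold lower number from compound 3 to compound 4 (0.35 log units; beyond the scatter). The estimate for compound 4 is 38000 nM, with an expected range from 13000 nM to 100000 nM.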

Compound 4, half-maximal inhibitory concentration: 65600 nM
Estimate against measurement, compound 4: 1.7-fold (0.24 log units) below, and the stated range covers the measured number.
By their numbers in this assay, from the lowest: compound 2; then compounds 1, 4 and 3 (each within the scatter of the next).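

In this assay, 3-bromophenyl on a saturated chain carbon bound to a sulfur stands level with 2,6-difluorophenyl, with a 1.3-fold lower number from compound 3 to compound 4 (0.11 log units; within the scatter), and with 4-nitrophenyl, with a 1.3-fold higher number from compound 1 to compound 4 (0.13 log units; within the scatter). Set against 2-fluorophenyl, however, it gives a 3.5-fold higher number from compound 2 to compound 4 (0.55 log units; beyond the scatter), so three differently substituted phenyl rings now form one group within the scatter of each other, and compound 2 alone gives a clearly lower number, which was less certain with only three compounds in hand. No supporting measurement bears on why compound 2 stands apart from the other three, so these numbers describe the pattern without explaining it.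

The compounds shown all keep a substituted phenyl ring at this place, so they leave open what an amine or a carboxylic acid on that ring would do, or a longer chain between the ring and the sulfur. They also leave open whether the lower number of compound 2 belongs to its single fluoro group in particular, as only one compound with that group is shown.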